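A Fourth Configuration at the Limit

The compounds below may be only part of what the source reports. "The series", "measured", "known", "first", "only" and "open" are said of these compounds alone.

Three stereoisomers have been followed in a physicochemical assay for metabolic stability, read by HPLC, with a stated time of 12 h, at pH 4.5; on this read-out higher numbers stand for a longer-lived compound and lower numbers for a shorter-lived compound. Compound 1 (`O=C(O)[C@H](CO)NC(=O)[C@H]1C[C@H](O)CN1`) gives > 12 h as a limit of the assay. Compound 2 (`O=C(O)[C@@H](CO)NC(=O)[C@H]1C[C@H](O)CN1`) gives > 12 h as a limit too. Compound 3 (`O=C(N[C@H](CO)C(=O)O)[C@@H]1C[C@H](O)CN1`) gives > 12 h and so also stands only at a limit. Compound 4 (`O=C(O)[C@H](CO)NC(=O)[C@@H]1C[C@H](O)CN1`) follows from compound 3 by one change (the two compounds have the same atoms and bonds and differ only in configuration as drawn: 1 of 3 stereo elements differ; a stereocentre at a saturated chain carbon is drawn R in compound 3 and S in compound 4). The closest measured step also turns a stereocentre at a saturated chain carbon (a step that the two limits leave unreadable from compound 1 to compound 2). Turning the stereocentre at a saturated ring carbon (a step that the two limits leave unreadable from compound 2 to compound 3) and turning both (a step that the two limits leave unreadable from compound 1 to compound 3) are the other two measured steps. None of the three has a readable size or direction. Compound 1, compound 2 and compound 3 all share one reading (the limit of > 12 h in this assay, at which 3 of the 3 values shown sit), so the data give no sign of an effect of configuration. No step beyond the scatter is expected in this assay (a step that the limit leaves unreadable from compound 3 to compound 4). Compound 4 is estimated at 20 h, with an expected range from 12 h to 40 h. A report as a limit is the expected outcome for compound 4.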

Compound 4, half-life: > 12 h
Compound 4 gave a limit, no number; the forecaster's own chance of this, stated with the estimate: 90%; the middle value lies beyond the limit too.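

In this assay, going by these compounds alone, compound 4 gives > 12 h, a limit and not a number, so no step linking it to compound 1, compound 2 or compound 3 can be read. The four compounds leave open whether turning either stereocentre changes the half-life at all: the limit of > 12 h in this assay, at which 4 of the 4 values shown sit.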